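Series notes: 3-aminophenyl in place of azetidin-3-yl

The compounds below may be only part of what the source reports. "The series", "measured", "known", "first", "only" and "open" are said of these compounds alone.

Compound 3 `FC(F)(F)c1cc(NCC2CNC2)c2cn[nH]c2c1` stands only at a limit in an assay for inhibition of Indoleamine 2,3-dioxygenase 1 (Homo sapiens), with stated times of 10 min and 60 min; on this read-out higher numbers stand for weaker inhibition and lower numbers for stronger inhibition: compound 3 gives > 100000 nM, a limit of the assay and not a number. The other two measured compounds sit at the same limit. Compound 1 `O=[N+]([O-])c1cccc(CNc2cc(C(F)(F)F)cc3[nH]ncc23)c1` gives > 100000 nM in this assay, again a limit. Compound 2 `FC(F)(F)c1cccc(CNc2cc(C(F)(F)F)cc3[nH]ncc23)c1` gives > 100000 nM in this assay, also a limit. Going by the values given here, the single measured step, a step that the two limits leave unreadable from compound 1 to compound 2, is therefore of unreadable size, since the limit of > 100000 nM in this assay, at which 3 of the 3 values shown sit, covers every value shown.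

Compound 4 `Nc1cccc(CNc2cc(C(F)(F)F)cc3[nH]ncc23)c1` has not yet been measured. It differs from compound 3 by 3-aminophenyl in place of azetidin-3-yl on a saturated chain carbon bound to a nitrogen on an aromatic ring. Among the compounds with values here, no measured step bears directly on this change, and the one step that exists, from compound 1 to compound 2, cannot be read. Across compounds 1, 2 and 3 the read-out has never moved off the limit, so there is no footing for expecting a step beyond the scatter in this assay, in either direction. Compound 4 is expected to give about 150000 nM in this assay, within 30000 nM to 1000000 nM, and most probably only as a limit. The implied step that the limit leaves unreadable from compound 3 to compound 4 is thus estimated as no readable change.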

Compound 4, half-maximal inhibitory concentration: > 100000 nM
Compound 4: no number, only a limit (the forecaster's own chance of this, stated with the estimate: 85%); the middle value does not contradict the limit.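

In this assay compound 4 gives > 100000 nM and this is a limit of the assay, not a number. Going by these compounds alone, no step to compound 4 from compound 1, compound 2 or compound 3 can be read, since one limit covers all four compounds: the limit of > 100000 nM in this assay, at which 4 of the 4 values shown sit. The compounds shown leave open which change, if any, would bring a value off this limit.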